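This account rests on a few compounds, and the source may have more. Where it says the series, first, only, none or still open, it means among the compounds named here.

Measured in an ADME assay on tissue (MDA-MB-231 cells, Homo sapiens) for pharmacokinetics; on this read-out lower numbers stand for a shorter-lived compound and higher numbers for a longer-lived compound
- compound 1 `CC(C)[C@H](N)C(=O)OC[C@H]1O[C@@H](n2cc(F)c(=O)[nH]c2=O)C[C@@H]1OC(=O)[C@@H](N)C(C)C` at 0.168 h
- compound 2 `N[C@@H](CCC(=O)O[C@H]1C[C@H](n2cc(F)c(=O)[nH]c2=O)O[C@@H]1CO)C(=O)O` at 0.138 h
- compound 3 `N[C@@H](CC(=O)O[C@H]1C[C@H](n2cc(F)c(=O)[nH]c2=O)O[C@@H]1CO)C(=O)O` at 0.322 h

Compound 3, at 0.322 h, lies within the scatter of compound 1 and beyond the scatter of compound 2. The change to compound 4 `CC(C)[C@H](N)C(=O)O[C@H]1C[C@H](n2cc(F)c(=O)[nH]c2=O)O[C@@H]1CO` is 1-amino-2-methylpropyl in place of 2-amino-2-carboxyethyl on a carbonyl carbon. Among the compounds with values here, one measured step touches this group, a 2.3-fold higher number from compound 2 to compound 3 (0.37 log units; beyond the scatter). It was modest, and it changes chain length without bringing in the entering group, so it informs size only. Within the data shown here, compound 1 also carries 1-amino-2-methylpropyl and gives 0.168 h, which points to a lower number, though no measured step links it to compound 4. A modest drop, near the scatter, is expected, with a 1.6-fold lower number from compound 3 to compound 4 (0.21 log units; within the scatter) as the estimated step. Compound 4 is estimated at 0.2 h, with an expected range of 0.1 h to 0.4 h.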

Compound 4, half-life: 0.248 h
Estimate against measurement, compound 4: 1.2-fold (0.09 log units) below, within the range that was stated.
By their numbers in this assay, from the lowest: compounds 2, 1, 4 and 3 (each within the scatter of the next, the first and the last beyond it).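

Three acyl variations on the shared core stay within the scatter in this assay: 1-amino-2-methylpropyl on a carbonyl carbon in place of 2-amino-2-carboxyethyl (a 1.3-fold lower number from compound 3 to compound 4 (0.11 log units; within the scatter)) or in place of 3-amino-3-carboxypropyl (a 1.8-fold higher number from compound 2 to compound 4 (0.25 log units; within the scatter)), and hydrogen in place of (1-amino-2-methylpropyl)carbonyl on an oxygen on a saturated carbon (a 1.5-fold higher number from compound 1 to compound 4 (0.17 log units; within the scatter)). The carboxylic acid and the second (1-amino-2-methylpropyl)carbonyl group are therefore not separated from their absence at this resolution. Nothing available accounts for these readings.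

From the compounds shown here alone, what a plain isobutyl group without the amine would give on that carbonyl carbon stays open, as does an amide in place of the ester.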